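Swapping Bromo for Methoxycarbonyl on a Kinase Inhibitor

This account rests on a few compounds, and the source may have more. Where it says the series, first, only, none or still open, it means among the compounds named here.

Measured in an assay on isolated protein for inhibition of Rho-associated protein kinase 2 (Homo sapiens), read by scintillation counting, radiometric assay and 33P incorporation, with a stated time of 40 min, in the presence of a further agent that is not named here; on this read-out lower numbers stand for stronger inhibition and higher numbers for weaker inhibition:
Compound 1, `COc1cc(OCC(=O)Nc2cccc(NC(=O)c3ccc(N(C)C)cc3)c2)ccc1C=O`, gives 306 nM.
Compound 2, `CCc1ccc(C(=O)Nc2cccc(NC(=O)COc3ccc4c(=O)ccoc4c3)c2)cc1`, gives 24 nM.
Compound 3, `O=C(COc1ccc2c(=O)ccoc2c1)Nc1cccc(NC(=O)c2ccc(Br)cc2)c1`, gives 49 nM.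

Compound 3 holds the second highest of these three numbers. Its nearest neighbour is compound 2, separated by the step of a 2.0-fold higher number from compound 2 to compound 3 (0.31 log units; beyond the scatter), where the change is bromo in place of ethyl on an aromatic carbon. The furthest is compound 1, whose number of 306 nM sits well apart, and compound 1 shares no single-point change with compound 3.

Compound 4, `COC(=O)c1ccc(C(=O)Nc2cccc(NC(=O)COc3ccc4c(=O)ccoc4c3)c2)cc1`, has not yet been measured. It differs from compound 3 in this way: methoxycarbonyl in place of bromo on an aromatic carbon. For the measured compounds named here, the only measured step at the same position is the ethyl-to-bromo change, a 2.0-fold higher number from compound 2 to compound 3 (0.31 log units; beyond the scatter), which was modest. Going by the values given here, no measured pair shows a methoxycarbonyl group, so the direction is uncertain; a modest step is expected, leaning towards a higher number, a 1.4-fold higher number from compound 3 to compound 4 (0.15 log units; within the scatter). For compound 4 the estimate in this assay is 70 nM, with a range from 20 nM to 250 nM.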

Compound 4, half-maximal inhibitory concentration: 29 nM
For compound 4 the middle estimate is 2.4-fold (0.38 log units) above the measured one; the range from low to high includes it.
By their numbers in this assay, from the lowest: compounds 2, 4 and 3 (each within the scatter of the next, the first and the last beyond it); then compound 1.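

Compound 4 shows that this position of the ring, para to a large group, can take methoxycarbonyl, with its 4 heavy atoms and 2 hydrogen-bond acceptors, in place of a single bromine atom with no change beyond the scatter in this assay: a 1.7-fold lower number from compound 3 to compound 4 (0.23 log units; within the scatter). The same holds against ethyl, a 1.2-fold higher number from compound 2 to compound 4 (0.08 log units; within the scatter), so the new group sits within the scatter of both earlier groups, even though those two lie just beyond the scatter of each other. Nothing measured here explains why these three groups give such close numbers.

Going by these compounds, whether a carboxylic acid, an amine or a longer ester chain at this position would stay this close remains open. Compound 1 differs from these compounds in more than one place, so it cannot settle that question.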